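From 3-fluorophenyl to 4-fluorophenyl

A few compounds are considered here, and "the series" means these few. Any claim that something is new, unique, unknown or untested is made for them only; others in the source may bear on it.

In a functional assay on B16-F10 cells (Mus musculus) for antiproliferative activity, read by MTT assay, with a stated time of 48 h (a lower number here means a stronger inhibitor, a higher number a weaker inhibitor), compound 1 `CC(=O)N1N=C(c2ccc3ccccc3c2)OC1c1ccc(Br)cc1` gives 4.68 ug/mL, compound 2 `CC(=O)N1N=C(c2ccc3ccccc3c2)OC1c1ccccc1Cl` gives 4.93 ug/mL, and compound 3 `CC(=O)N1N=C(c2ccc3ccccc3c2)OC1c1cccc(F)c1` gives 1.61 ug/mL, the lowest of the three numbers. Compound 4 `CC(=O)N1N=C(c2ccc3ccccc3c2)OC1c1ccc(F)cc1` carries 4-fluorophenyl in place of 3-fluorophenyl on a saturated ring carbon. Among the compounds with values here, no measured step makes this exact swap. The nearest evidence is a 2.9-fold lower number from compound 1 to compound 3 (0.46 log units; beyond the scatter), which links 3-fluorophenyl with 4-bromophenyl, and a 3.1-fold lower number from compound 2 to compound 3 (0.49 log units; beyond the scatter). Both are modest but beyond the scatter. Compound 4 may lose part of that advantage, so a small rise is expected. The expected step is a 1.7-fold higher number from compound 3 to compound 4 (0.24 log units; within the scatter). Compound 4 is estimated at 2.8 ug/mL, within an expected range of 1.2 ug/mL to 6 ug/mL.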

Compound 4, half-maximal inhibitory concentration: 4.65 ug/mL
Beside the measured number, compound 4's estimate is 1.7-fold (0.22 log units) below it; measured number inside the range.
By their numbers in this assay, from the lowest: compound 3; then compounds 4, 1 and 2 (each within the scatter of the next).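

In this assay the place of the fluorine on the phenyl ring counts, not merely its presence, with a 2.9-fold higher number from compound 3 to compound 4 (0.46 log units; beyond the scatter) even though both compounds hold the same atoms. 4-Fluorophenyl stands level with the two other groups, with a 1.1-fold lower number from compound 2 to compound 4 (0.03 log units; within the scatter) and a 1.0-fold lower number from compound 1 to compound 4 (0.00 log units; within the scatter), so among these four compounds only 3-fluorophenyl stands apart. Nothing measured here explains this difference. Going by these compounds, whether 3-chlorophenyl or 3-methoxyphenyl would match the low number of compound 3 remains open.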